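A few compounds are considered here, and "the series" means these few. Any claim that something is new, unique, unknown or untested is made for them only; others in the source may bear on it.

Measured so far in a functional assay on MCF7 cells (Homo sapiens) for cytotoxicity, read by MTT assay, with a stated time of 2 days, tested at 10 uM; a lower number here means a stronger effect, a higher number a weaker effect of the compound at the concentration tested:

compound 1 `CC(=O)c1cc(-c2ccccc2)cc2cc(-c3ccc(F)cc3)[nH]c12`: 91.9%
compound 2 `COc1ccc(-c2cc(C(C)=O)c3[nH]c(-c4ccc(F)cc4)cc3c2)cc1`: 52.9%
compound 3 `CC(=O)c1cc(/C=C/c2ccccc2)cc2cc(-c3ccccc3)[nH]c12`: 86.5%

Compound 3 stands second highest of the three numbers in this assay. Its nearest neighbour is compound 1, which gives a number higher by an amount within the scatter, so the two are not distinguishable here. The furthest is compound 2, which lies well beyond the scatter below compound 3. Within the data shown here, the one step between compounds differing in a single place, a number 39 percentage points lower from compound 1 to compound 2 (beyond the scatter), concerns a methoxy in place of hydrogen on an aromatic carbon and so does not bear on the change considered next.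

Compound 4 `CC(=O)c1cc(/C=C/c2ccccc2)cc2cc(-c3ccc(F)cc3)[nH]c12`, not yet measured, differs from compound 3 in this respect: fluoro in place of hydrogen on an aromatic carbon

The same difference, phenyl to 4-fluorophenyl, is not covered by any measured step; compound 1 carries the 4-fluorophenyl and compound 3 the phenyl, but the two also differ elsewhere, so only their values can be compared, and these lie within the scatter of one another. No step beyond the scatter is therefore expected in this assay. For compound 4 the estimated value is 88%, with a range from 72% to 100%. The expected step is a number 1.5 percentage points higher from compound 3 to compound 4 (within the scatter).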

Compound 4, a percentage reported as activity, at one concentration (the size of the read-out at that concentration, not a potency): 69.5%
The estimate for compound 4 lay 18.5 percentage points above the measured number; the measured number lies below the stated range.
By their numbers in this assay, from the lowest: compound 2; then compound 4; then compounds 3 and 1 (each within the scatter of the next).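

In this assay the ring carrying the new fluoro does respond to a single change: phenyl to 4-fluorophenyl, with the fluoro para to a large group, gives a number 17 percentage points lower from compound 3 to compound 4 (beyond the scatter) on the 2-phenylethenyl background. With the 4-fluorophenyl held fixed, the other aromatic substituent also matters, since 2-phenylethenyl in place of phenyl gives a number 22.4 percentage points lower from compound 1 to compound 4 (beyond the scatter) and 2-phenylethenyl in place of 4-methoxyphenyl gives a number 16.6 percentage points higher from compound 2 to compound 4 (beyond the scatter), which places compound 4 between compound 2 and compound 1 in this assay. Nothing available on these compounds explains either the fluoro step or the two substituent steps.

The compounds shown leave open whether fluoro in place of hydrogen has a similar effect when the other aromatic substituent is phenyl or 4-methoxyphenyl, as no matched pair without the fluoro exists on either background. Also open, from the compounds shown here alone, is whether the response at this ring is specific to fluoro or extends to other groups at the same place, such as chloro, methoxy or an amine.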